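From a Saturated Ring to 2-Methoxyphenyl

A few compounds are considered here, and "the series" means these few. Any claim that something is new, unique, unknown or untested is made for them only; others in the source may bear on it.

Among the measured compounds shown here, in an ADME assay on MDBK cells (Bos taurus) for cytotoxicity, read by MTT assay (on this read-out higher numbers stand for lower toxicity in this test and lower numbers for higher toxicity in this test), compound 3 `CCC1CCCCC1OCCCCCCN1C[C@H](O)[C@@H](O)[C@H](O)[C@H]1CO` gives 450000 nM, the only actual number among the three measured compounds. Compound 1 `CCC1CCC(OCCCCCCN2C[C@H](O)[C@@H](O)[C@H](O)[C@H]2CO)CC1` reads > 500000 nM, which is a limit. Compound 2 `CC1CCC(OCCCCCCN2C[C@H](O)[C@@H](O)[C@H](O)[C@H]2CO)CC1C` reads > 500000 nM, also a limit. Compound 4 `COc1ccccc1OCCCCCCN1C[C@H](O)[C@@H](O)[C@H](O)[C@H]1CO` replaces the saturated ring group of compound 3 with 2-methoxyphenyl: a group of 8 heavy atoms (7 carbon, 1 oxygen; one six-membered aromatic ring of carbon only) in place of a group of 8 heavy atoms (8 carbon; one six-membered non-aromatic ring of carbon only), on an oxygen on a saturated carbon. The nearest measured steps swap one saturated ring group for another: an at least 1.1-fold lower number from compound 1 to compound 3 (0.04 log units; that floor lies within the scatter), and an at least 1.1-fold lower number from compound 2 to compound 3 (0.04 log units; that floor lies within the scatter). Neither floor goes beyond the scatter, and neither step introduces an aromatic ring, so they offer only modest guidance. The expected change in this assay is no change at the digits printed from compound 3 to compound 4 (within the scatter), with no shift beyond the scatter anticipated. For compound 4, the estimated value is 450000 nM, with an expected range from 200000 nM to 800000 nM.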

Compound 4, half-maximal cytotoxic concentration: > 500000 nM
Compound 4: no number, only a limit; the forecaster's own chance of this, stated with the estimate: 45%; middle value at least 1.1-fold (0.04 log units) from the limit.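

Among the compounds shown here, with 2-methoxyphenyl on this oxygen, an aromatic ring carrying one hydrogen-bond acceptor takes the place of the saturated carbon rings of the earlier compounds, and the step in this assay is an at least 1.1-fold higher number from compound 3 to compound 4 (0.04 log units; that floor lies within the scatter). This change therefore gives no sign of greater toxicity in this test, but the steps from compound 1 and compound 2 to compound 4 cannot be read. Any true differences stay hidden because of the assay's ceiling: the limit of > 500000 nM in this assay, at which 3 of the 4 values shown sit.

Still open, going by these compounds, is whether a phenyl ring bearing an amine or a carboxylic acid instead of methoxy would give a readable number in this assay.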